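A few compounds are considered here, and "the series" means these few. Any claim that something is new, unique, unknown or untested is made for them only; others in the source may bear on it.

Working notes on the series, read in a physicochemical assay for lipophilicity, read by HPLC, at pH 7.5; on this read-out lower numbers stand for lower lipophilicity and higher numbers for higher lipophilicity. Among the measured compounds shown here, compound 1 `CC[C@@H](Nc1c(C#N)c(-c2ccc(-c3cccc(C)c3)cc2)nc2cnccc12)C(N)=O` gives 3 and compound 2 `CC[C@@H](Nc1c(C#N)c(-c2ccc(Br)cc2)nc2cnccc12)C(N)=O` gives 2.2, so compound 2 holds the lower of the two numbers so far, with a gap beyond the scatter. Compound 3 `CC[C@@H](Nc1c(C#N)c(-c2ccc(-c3cccc(OC)c3)cc2)nc2cnccc12)C(N)=O` is reached from compound 2 by this change: 3-methoxyphenyl in place of bromo on an aromatic carbon.

For the measured compounds named here, the only measured step that bears on this change is a number 0.80 log units lower from compound 1 to compound 2 (beyond the scatter), a modest step beyond the scatter, with bromo replacing 3-methylphenyl on an aromatic carbon. Read in reverse, it comes close to the present change, since the entering group is 3-methoxyphenyl rather than 3-methylphenyl. Going by the values given here, no measured pair isolates that difference between the two entering groups, so this single step is the whole basis for the size. A rise of similar size, beyond the scatter, is therefore expected in this assay, and the value of compound 1 at 3 serves as the nearest guide. The expected step is a number 0.70 log units higher from compound 2 to compound 3 (beyond the scatter). For compound 3 the estimated value is 2.9, with an expected range of 2.5 to 3.3.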

Compound 3, distribution coefficient: 2.7
Compound 3: the middle estimate sits 0.20 log units above what was measured; the measured number falls inside the stated range.
By their numbers in this assay, from the lowest: compound 2; then compounds 3 and 1 (each within the scatter of the next).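

In this assay, the rise on replacing bromo now holds for a second entering group: a number 0.50 log units higher from compound 2 to compound 3 (beyond the scatter), and this sits alongside a number 0.80 log units lower from compound 1 to compound 2 (beyond the scatter), so among these three compounds, compound 2, the one carrying bromo, has the lowest number, and no compound here goes against that. Among the compounds shown here, the exchange on the outer ring, read directly for the first time, does not separate the two entering groups: a number 0.30 log units lower from compound 1 to compound 3 (within the scatter), so methoxy and methyl cannot be ordered on this read-out. The measurements in hand offer no explanation for either step.

From the compounds shown here alone, it remains open whether this pattern extends beyond 3-methylphenyl and 3-methoxyphenyl, since both entering groups are six-membered aromatic rings of carbon only, each carrying one small substituent. A phenyl ring carrying an amine or a carboxylic acid in place of the methoxy, or a longer alkoxy chain there, would test whether the number at this position can move further in either direction, and a saturated ring in place of the aromatic one would test whether the rise requires an aromatic ring at all.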